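Dimethylamino to Methyl(oxan-4-yl)amino on a Shared Core

This account rests on a few compounds, and the source may have more. Where it says the series, first, only, none or still open, it means among the compounds named here.

Of the compounds shown here, two with the same core have been measured in an ADME assay on microsomes from liver (Mus musculus) for metabolic stability, using NADPH, with a stated time of 10 min; a higher number here means that more of the compound is left, a lower number that less of the compound is left. Compound 1 `NC(=O)NCCCCN(C[C@H]1Cc2ncccc2CN1)[C@H]1CCCc2cccnc21`, which carries a ureido group on its chain, gives 32%. Compound 2 `CN(C)CCCCN(C[C@H]1Cc2ncccc2CN1)[C@H]1CCCc2cccnc21`, with dimethylamino in that place, gives 55%, the higher of the two numbers.

Compound 3 `CN(CCCCN(C[C@H]1Cc2ncccc2CN1)[C@H]1CCCc2cccnc21)C1CCOCC1` changes compound 2 at that same group: oxan-4-yl in place of methyl on an amine nitrogen. Oxan-4-yl takes the place of methyl on an amine nitrogen, so dimethylamino becomes methyl(oxan-4-yl)amino.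

Going by the values given here, only one measured step bears on this, a number 23 percentage points higher from compound 1 to compound 2 (beyond the scatter). It swapped the whole group on the chain and shows that this assay can respond to a change there. Among the compounds with values here, no measured step replaces a methyl on this nitrogen, so neither its size nor its direction carries over directly. The change here is narrower, and a smaller step is expected, leaning slightly lower but probably not beyond the scatter. The expected step is a number 8 percentage points lower from compound 2 to compound 3 (within the scatter). For compound 3 the estimated value is 47%, with an expected range from 27% to 65%.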

Compound 3, percent of the compound remaining: 51%
Estimate against measurement, compound 3: 4 percentage points below; the measured number falls inside the stated range.
By their numbers in this assay, from the lowest: compound 1; then compounds 3 and 2 (each within the scatter of the next).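

In this assay the swap of methyl for oxan-4-yl on the amine nitrogen gives a number 4 percentage points lower from compound 2 to compound 3 (within the scatter) and so shows that this position takes a group of six heavy atoms with a six-membered non-aromatic ring without a difference that can be told apart from the scatter. Set against ureido on the same saturated chain carbon, methyl(oxan-4-yl)amino gives a number 19 percentage points higher from compound 1 to compound 3 (beyond the scatter) and thus joins dimethylamino in standing apart from compound 1, so the earlier step beyond the scatter is no longer tied to dimethylamino alone. No measurement offered here explains either step, and the numbers remain a description of what was seen.

What the compounds shown leave open is whether cyclohexyl, which has carbon where oxan-4-yl has its ring oxygen, or a larger group such as a benzyl on this nitrogen would give a number in this assay that also stays within the scatter of compound 2. They also leave open how a longer chain between the two amine nitrogens, or a carboxylic acid in place of the amine at its end, would read in this assay.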